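Benzyl to 4-chlorophenyl with 2-hydroxyethoxy retained

The source may report more compounds than this note shows. Statements on the series, on what has been measured and on what is new or still open speak of the compounds shown alone.

In a functional assay on SK-MEL-28 cells (Homo sapiens) for cytotoxicity, read by CCK-8 assay, with a stated time of 24 h (on this read-out lower numbers stand for stronger inhibition and higher numbers for weaker inhibition), compound 3 `COc1ccccc1Oc1c(N)nc(Cc2ccccc2)nc1OCCO` gives 14000 nM, the second highest of three numbers. Compound 1 `COc1ccccc1Oc1c(N)nc(-c2ccc(F)cc2)nc1Cl` gives 31900 nM, and compound 2 `COc1ccccc1Oc1c(N)nc(-c2cccc(I)c2)nc1Cl` gives 4660 nM. Compound 4 `COc1ccccc1Oc1c(N)nc(-c2ccc(Cl)cc2)nc1OCCO` carries 4-chlorophenyl in place of benzyl on an aromatic carbon. Among the measured compounds shown here, no measured step makes this exact change, and compound 1 and compound 2 both lack the 2-hydroxyethoxy group. For the measured compounds named here, the only measured step, a 6.8-fold lower number from compound 1 to compound 2 (0.84 log units; beyond the scatter), exchanges one halogenated phenyl for another, so it shows how far the aryl group alone can move the number, but gives no direction here. The expected result is a 1.4-fold lower number from compound 3 to compound 4 (0.15 log units; within the scatter), with no step beyond the scatter anticipated. For compound 4 the estimated value is 10000 nM, with an expected range of 3500 nM to 30000 nM.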

Compound 4, half-maximal inhibitory concentration: > 80000 nM
Compound 4 ended at the assay's limit (the forecaster's own chance of this, stated with the estimate: 5%); at least 8.0-fold (0.90 log units) between middle value and limit.
By their numbers in this assay, from the lowest: compound 2; then compound 3; then compound 1. At a limit, above all of these: compound 4.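

Compound 4 gives > 80000 nM in this assay, and this is a limit of the assay, not a number: the limit of > 80000 nM in this assay, at which 1 of the 4 values shown sits.

With 2-hydroxyethoxy retained, changing the group on the carbon between two ring nitrogen atoms gives an at least 5.7-fold higher number from compound 3 to compound 4 (0.75 log units; beyond the scatter). The earlier step, a 6.8-fold lower number from compound 1 to compound 2 (0.84 log units; beyond the scatter), exchanged one halogenated phenyl for another; this one shows that benzyl to 4-chlorophenyl also moves the number beyond the scatter, upward, although both groups have 7 heavy atoms.

Still open, going by these compounds, is how 3-iodophenyl behaves with 2-hydroxyethoxy retained. Also open, on these data alone, is where a 2-phenylethyl group or an amine such as morpholine on this carbon would fall.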